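Replacing a Six-Membered Ring with an Allyl Chain

The source may hold more compounds than are shown below. What is called first, only, known or untested is meant among the compounds shown, and "the series" means these compounds.

Compound 1 `C[C@H](NC(=O)c1cnnn1Cc1ccc(C(F)(F)F)cc1)c1ccc(C(=O)O)cc1` in a functional assay on CHO cells for antagonist activity at prostaglandin E2 receptor EP4 subtype (Homo sapiens), read by calcium flux, with a stated time of 15 min (a lower number here means a stronger inhibitor, a higher number a weaker inhibitor), gives > 10000 nM, which is a limit of the assay rather than a number.
Compound 2 `C[C@H](NC(=O)c1c(C2CCCC2)nnn1Cc1ccc(C(F)(F)F)cc1)c1ccc(C(=O)O)cc1` gives 65.1 nM.
Compound 3 `C[C@H](NC(=O)c1c(C2=CCOCC2)nnn1Cc1ccc(C(F)(F)F)cc1)c1ccc(C(=O)O)cc1` gives 119 nM.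

Of the two numbers measured, compound 3 has the higher one, but its nearest neighbour is compound 2, and a 1.8-fold higher number from compound 2 to compound 3 (0.26 log units; within the scatter), so the two cannot be told apart. Compound 4 `C=CCc1nnn(Cc2ccc(C(F)(F)F)cc2)c1C(=O)N[C@@H](C)c1ccc(C(=O)O)cc1` differs from compound 3 in one place: a group of 3 heavy atoms (3 carbon; no ring) in place of a group of 6 heavy atoms (5 carbon, 1 oxygen; one six-membered non-aromatic ring with 1 hetero atom), on an aromatic carbon. Going by the values given here, two measured steps bear on this. Starting from compound 1, whose value is only a limit, an at least 150-fold lower number from compound 1 to compound 2 (2.18 log units; beyond the scatter) and an at least 84-fold lower number from compound 1 to compound 3 (1.92 log units; beyond the scatter): any of the groups tried on that aromatic carbon in place of hydrogen gives a far stronger inhibitor. Between the two groups themselves the step is small, as a 1.8-fold higher number from compound 2 to compound 3 (0.26 log units; within the scatter) shows. Among the compounds with values here, an allyl group, with three carbons and no ring, is smaller than either; no measured compound tells how small a group still suffices. Compound 4 is therefore expected to remain much stronger than compound 1 but somewhat weaker than compound 3, with a 2.1-fold higher number from compound 3 to compound 4 (0.32 log units; beyond the scatter). The estimate for compound 4 is 250 nM, within 70 nM to 900 nM.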

Compound 4, half-maximal inhibitory concentration: > 1000 nM
Compound 4: a limit, no number; the forecaster's own chance of this, stated with the estimate: 5%; middle value at least 4.0-fold (0.60 log units) from the limit.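

In this assay, the allyl group on this aromatic carbon falls well short of both ring-bearing groups (an at least 8.4-fold higher number from compound 3 to compound 4 (0.92 log units; beyond the scatter); an at least 15-fold higher number from compound 2 to compound 4 (1.18 log units; beyond the scatter)). Going by these compounds alone, the earlier compounds showed only that the two ring-bearing groups in place of hydrogen each gave a far stronger inhibitor and could not be told apart, whereas compound 4 shows that the choice of group here matters. The value of compound 4 is a limit of the assay, not a number: the limit of > 1000 nM in this assay, at which 1 of the 4 values shown sits.

From the compounds shown here alone, the step from compound 1 to compound 4 cannot be read, as both ends are limits, so whether allyl keeps any of the gain over hydrogen remains unknown. Going by these compounds, it also remains open whether a longer chain such as butyl, or a small ring such as cyclopropyl, would bring the number back down.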